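The source may report more compounds than this note shows. Statements on the series, on what has been measured and on what is new or still open speak of the compounds shown alone.

Measured compounds:
compound 1 `CC1=CC[C@H](C(C)C)c2cc(C)c(OC(=O)Nc3ccccc3)cc21` – 100%
compound 2 `COc1cccc(C(=O)Oc2cc3c(C)ccc(C(C)C)c3cc2C)c1` – "not active" (no number reported)

Going by the values given here, in a functional assay on U-251 cells (Homo sapiens) for antiproliferative activity, read by sulforhodamine B assay, with a stated time of 48 h, tested at 50 uM (on this read-out lower numbers stand for less inhibition and higher numbers for more inhibition at the one concentration tested (going by the name of the read-out)), compound 1 gives 100%, the only number, while compound 2 gives "not active" (no number reported) without a number and on a different core. Compound 3 `CC1=CC[C@H](C(C)C)c2cc(C)c(OC(=O)c3cccc([N+](=O)[O-])c3)cc21` keeps the core of compound 1 and differs by 3-nitrophenyl in place of anilino on a carbonyl carbon. Among the compounds with values here, no measured pair differs in one place, so the size of this step is open. Because compound 1 stands at 100% and compound 2 reports "not active" (no number reported), a fall beyond the scatter is expected. Compound 3 is estimated at 55%, range 10% to 95%, an expected step of a number 45 percentage points lower from compound 1 to compound 3 (beyond the scatter).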

Compound 3, a percentage reported as inhibition, at one concentration (the size of the read-out at that concentration, not a potency): 44%
The estimate for compound 3 lay 11 percentage points above the measured number, within the range that was stated.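

In this assay, the position on the carbonyl carbon responds to substitution on the shared core: 3-nitrophenyl in place of anilino gives a number 56 percentage points lower from compound 1 to compound 3 (beyond the scatter). Inhibition is reduced but not abolished, as compound 3 still gives 44%. No evidence available here ties this fall to any feature of the change.

The step removes anilino and introduces the nitro group together, so the two remain unseparated. A plain phenyl on the carbonyl carbon of the same core would address that question.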